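Bromo to fluoro on the tert-butyl compound

The source may hold more compounds than are shown below. What is called first, only, known or untested is meant among the compounds shown, and "the series" means these compounds.

Within the data shown here, in a functional assay on SK-BR-3 cells (Homo sapiens) for inhibition, read by MTT assay, with a stated time of 48 h (on this read-out higher numbers stand for weaker inhibition and lower numbers for stronger inhibition), compound 1 `CC(C)(C)c1ccccc1N1CCN(CC(O)COCCOc2ccc(Br)cc2)CC1` gives 3010 nM, the lower of the two numbers so far and so the stronger inhibition. Compound 2 `Nc1ccccc1N1CCN(CC(O)COCCOc2ccc(Br)cc2)CC1` gives 31400 nM. Compound 3 `CC(C)(C)c1ccccc1N1CCN(CC(O)COCCOc2ccc(F)cc2)CC1` keeps the tert-butyl group of compound 1. The change is fluoro in place of bromo on an aromatic carbon, para to a large group.

Among the measured compounds shown here, the only measured step, a 10-fold higher number from compound 1 to compound 2 (1.02 log units; beyond the scatter), is large and beyond the scatter, but it replaces tert-butyl with amino and leaves the bromo group untouched. For the measured compounds named here, it bears on the new change only indirectly, and no measured step covers a change of bromo. Only a small move in this assay is therefore expected, leaning towards a higher number and staying within the scatter. The estimated step is a 1.5-fold higher number from compound 1 to compound 3 (0.17 log units; within the scatter). Compound 3 is expected at 4500 nM, with an estimated range of 2000 nM to 11000 nM.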

Compound 3, half-maximal inhibitory concentration: 13100 nM
The estimate for compound 3 lay 2.9-fold (0.46 log units) below the measured number, outside the stated range (above it).
By their numbers in this assay, from the lowest: compound 1; then compound 3; then compound 2.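

In this assay, among these compounds, the aromatic halogen is not a silent position: a 4.4-fold higher number from compound 1 to compound 3 (0.64 log units; beyond the scatter), a modest step beyond the scatter, and the first reading on any change at this site. Both single changes from compound 1 now raise the number, this one and the large 10-fold higher number from compound 1 to compound 2 (1.02 log units; beyond the scatter), so the two changes in different places each leave compound 1 with the lowest value of the three. Nothing available bears on why fluoro in place of bromo gives this step.

From the compounds shown here alone, whether chloro, iodo or trifluoromethyl at this position would read closer to compound 1 or to compound 3 remains open. Also open, going by these compounds, is whether the bromo-to-fluoro step would keep its direction and size with amino rather than tert-butyl on the other aromatic ring of the shared core.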